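Swapping the amide end group: from compound 3 to compound 4

A few compounds are considered here, and "the series" means these few. Any claim that something is new, unique, unknown or untested is made for them only; others in the source may bear on it.

Measured compounds:
compound 1 `CC(C)(C)c1ccc(C(=O)N2CCC3(CC2)C(=O)N(CC(=O)N2CCNCC2)CN3c2ccccc2)cc1` gives 22000 nM
compound 2 `CC(C)(C)OC(=O)NCCCCCNC(=O)CN1CN(c2ccccc2)C2(CCN(C(=O)c3ccc(C(C)(C)C)cc3)CC2)C1=O` gives 13700 nM
compound 3 `CC(C)(C)c1ccc(C(=O)N2CCC3(CC2)C(=O)N(CC(=O)N2CCCC(C(N)=O)C2)CN3c2ccccc2)cc1` gives 16900 nM

All three compounds share one core and differ only in the group attached at a carbonyl carbon at the end of a short chain. In an assay on HEK293 cells for displacement of a labelled ligand from NPC1-like intracellular cholesterol transporter 1 (Homo sapiens) (a lower number here means a stronger inhibitor, a higher number a weaker inhibitor), compound 3 sits between the others, but all three numbers lie within the usual scatter of one another, so none of them can be called stronger or weaker than the rest.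

Compound 4 `CC(C)(C)c1ccc(C(=O)N2CCC3(CC2)C(=O)N(CC(=O)NCCC(=O)O)CN3c2ccccc2)cc1` has not yet been measured. Its difference from compound 3 is (2-carboxyethyl)amino in place of 3-carbamoylpiperidin-1-yl on a carbonyl carbon. Within the data shown here, the one measured step at this position, a 1.3-fold lower number from compound 1 to compound 3 (0.11 log units; within the scatter), was within the scatter. Compound 2, whose variation sits at the same place, shows a value that also lies close to compound 3. The available steps therefore give no sign that changing this end group moves the number beyond the scatter in either direction, and the expectation is a step of about a 1.0-fold higher number from compound 3 to compound 4 (0.00 log units; within the scatter), essentially none.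

Compound 4 is expected to give 17000 nM, with a range from 6000 nM to 45000 nM.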

Compound 4, half-maximal inhibitory concentration: 11400 nM
The estimate for compound 4 lay 1.5-fold (0.17 log units) above the measured number; low and high end bracket the measured number.
By their numbers in this assay, from the lowest: compounds 4, 2, 3 and 1 (each within the scatter of the next).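

In this assay, replacing the ring-bearing 3-carbamoylpiperidin-1-yl end group with a carboxylic acid on a short open chain gives a 1.5-fold lower number from compound 3 to compound 4 (0.17 log units; within the scatter) and leaves the number within the scatter. The comparisons with the two other end groups, a 1.2-fold lower number from compound 2 to compound 4 (0.08 log units; within the scatter) and a 1.9-fold lower number from compound 1 to compound 4 (0.29 log units; within the scatter), are also within the scatter, so this acid joins the piperazin-1-yl group, the 3-carbamoylpiperidin-1-yl group and the tert-butoxycarbonyl-capped chain of compound 2 without separating from any of them. This position has now taken end groups with and without a ring, and with an amide or a carboxylic acid at the end, with no clear change in the number, and no measurement at hand explains this flat picture.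

From the compounds shown here alone, what remains open is whether any end group at this position can move the number beyond the scatter in either direction. A free primary amine at the end of the five-carbon chain of compound 2, a methyl ester of the acid in compound 4, or a longer chain carrying the same carboxylic acid would each test this further.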